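Swapping 4-cyanophenyl for amino on a sulfonyl sulfur

The compounds below may be only part of what the source reports. "The series", "measured", "known", "first", "only" and "open" are said of these compounds alone.

In an ADME assay on microsomes from liver (Mus musculus) for metabolic stability, read by LC-MS, with NADPH named in the record, with a stated time of 60 min, tested at 1 uM, in the absence of a further agent (on this read-out higher numbers stand for a more stable compound and lower numbers for a less stable compound), compound 1 (`COc1ccc(-c2c(C)nc3c(N4CC[C@@H](NC(=O)C(F)(F)F)C4)cc(C)nn23)cc1OC`) gives > 95% as a limit of the assay. Among the compounds with values here, compound 2 (`COc1ccc(-c2c(C)nc3c(N4CC[C@@H](NS(=O)(=O)c5ccc(C#N)cc5)C4)cc(C)nn23)cc1OC`) gives > 95% as a limit too, so it stands level with the only other compound measured, as the limit of > 95% in this assay, at which 2 of the 2 values shown sit, shows. Within the data shown here, the one measured step, a step that the two limits leave unreadable from compound 1 to compound 2, therefore offers no size to carry forward. Compound 3 (`COc1ccc(-c2c(C)nc3c(N4CC[C@@H](NS(N)(=O)=O)C4)cc(C)nn23)cc1OC`) has amino in place of 4-cyanophenyl on a sulfonyl sulfur. The estimated step of a number at least 3 percentage points lower from compound 2 to compound 3 (that floor lies within the scatter) is expected to stay within the scatter, with no direction foreseen. For compound 3 the expected value is 92%, with an estimated range from 78% to 100% of compound remaining.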

Compound 3, percent of the compound remaining: > 95%
Compound 3 was reported as a limit; the forecaster's own chance of this, stated with the estimate: 50%; middle value at least 3 percentage points from the limit.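

The steps among compound 1, compound 2 and compound 3 cannot be read in this assay, because all three sit at one limit: the limit of > 95% in this assay, at which 3 of the 3 values shown sit.

The compounds shown leave open whether their stability truly differs, and which change would bring a compound off that limit.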